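A few compounds are considered here, and "the series" means these few. Any claim that something is new, unique, unknown or untested is made for them only; others in the source may bear on it.

Measured compounds:
- compound 1, `COc1cccc(OC)c1C(=O)Nc1c[nH]nc1C(=O)NC1CCCCCC1`: 42000 nM
- compound 2, `CO[C@H]1CC[C@H](NC(=O)c2n[nH]cc2NC(=O)c2ccccc2C(F)(F)F)CC1`: 3300 nM
- compound 3, `CO[C@H]1CC[C@H](NC(=O)c2n[nH]cc2NC(=O)c2ccccc2)CC1`: 800 nM

In an ADME assay on MRC5 cells (Homo sapiens) for inhibition, with a stated time of 72 h (a higher number here means that more compound is needed for the effect, a lower number that less compound is needed), compound 1 gives the highest of the three numbers, so the most compound is needed for the effect; compound 2 sits nearer to it and compound 3 furthest away, both well beyond the scatter. Going by the values given here, the only step seen between measured compounds is a 4.1-fold lower number from compound 2 to compound 3 (0.62 log units; beyond the scatter), a change on the aromatic ring of the other amide in the shared core.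

Compound 4, `COc1cccc(OC)c1C(=O)Nc1c[nH]nc1C(=O)Nc1ccccn1`, differs from compound 1 in one place: pyridin-2-yl in place of cycloheptyl on an amide-type nitrogen. Among the compounds with values here, no measured step touches this position, and the change from compound 2 to compound 3 concerns a different part of the molecule, so it gives no guide to size or direction here. Any expectation therefore rests on compound 1 alone and is broad. The estimate for compound 4 is 20000 nM, with a range from 4000 nM to 100000 nM. That estimate means an expected step of a 2.1-fold lower number from compound 1 to compound 4 (0.32 log units; beyond the scatter), which may well lie within the scatter.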

Compound 4, half-maximal effective concentration: > 50000 nM
Compound 4: a limit, no number; the forecaster's own chance of this, stated with the estimate: 25%; at least 2.5-fold (0.39 log units) between middle value and limit.
By their numbers in this assay, from the lowest: compound 3; then compound 2; then compound 1. At a limit, above all of these: compound 4.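

In this assay, compound 4 gives > 50000 nM, which is a limit of the assay and not a number. Going by these compounds alone, this provides the first measured step at this position: putting pyridin-2-yl in place of cycloheptyl on the amide-type nitrogen gives an at least 1.1-fold higher number from compound 1 to compound 4 (0.07 log units; that floor lies within the scatter). Going by these compounds, the step is only a floor and that floor lies within the scatter, so the swap shows no fall in the amount of compound needed, while the true size of any rise remains unknown.

A phenyl group on the same nitrogen could help separate the part played by the aromatic ring from that of the ring nitrogen in pyridin-2-yl. On these data alone, it also remains open how a simple open carbon chain or a group carrying an amine would fare at this position.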